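Adding phenyl to a series held at the limit

A few compounds are considered here, and "the series" means these few. Any claim that something is new, unique, unknown or untested is made for them only; others in the source may bear on it.

In a functional assay on MCF7 cells (Homo sapiens) for antiproliferative activity, read by MTT assay, with a stated time of 48 h (on this read-out higher numbers stand for weaker inhibition and lower numbers for stronger inhibition), compound 3 (`COc1ccc(-c2nc(Cl)cc(Nc3ccc(NC(=O)CN(C)C)cc3)n2)cc1`) gives > 40000 nM as a limit and not a number. Compound 1 (`CCN(CC)CC(=O)Nc1ccc(Nc2nc(-c3ccc(OC)cc3)nc(Cl)c2-c2ccccc2)cc1`) gives > 40000 nM as a limit too. Compound 2 (`COc1ccc(-c2nc(Cl)c(-c3ccccc3)c(Nc3ccc(NC(=O)CN4CCCC4)cc3)n2)cc1`) gives > 40000 nM as a limit as well. The three compounds thus share one reading (the limit of > 40000 nM in this assay, at which 3 of the 3 values shown sit) and compound 3 offers no number to start from. For the measured compounds named here, the only measured step (a step that the two limits leave unreadable from compound 1 to compound 2) has no readable size, so no measured step sizes the change ahead.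

Compound 4 (`COc1ccc(-c2nc(Cl)c(-c3ccccc3)c(Nc3ccc(NC(=O)CN(C)C)cc3)n2)cc1`) differs from compound 3 by phenyl in place of hydrogen on an aromatic carbon. In this assay compound 2, which carries a phenyl on the shared core, still gives > 40000 nM as a limit. On that reading no step beyond the usual scatter is expected (a number no higher from compound 3 to compound 4 (the limit leaves the size open)) in either direction. For compound 4 the expected value is 40000 nM with an estimated range from 15000 nM to 60000 nM and a report of the limit alone would be no surprise.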

Compound 4, half-maximal inhibitory concentration: 17700 nM
Beside the measured number, compound 4's estimate is 2.3-fold (0.35 log units) above it, within the range that was stated.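

In this assay, phenyl in place of hydrogen on the aromatic carbon ortho to a chloro group brings the series off its limit, with an at least 2.2-fold lower number from compound 3 to compound 4 (0.35 log units; beyond the scatter) as the step. That phenyl does not act alone, since the chain amine also counts: dimethylamino in place of pyrrolidin-1-yl gives an at least 2.2-fold lower number from compound 2 to compound 4 (0.35 log units; beyond the scatter) as its step, and dimethylamino in place of diethylamino gives an at least 2.2-fold lower number from compound 1 to compound 4 (0.35 log units; beyond the scatter) as its step. As far as these compounds go, all three sizes stay open at one end, because each starting compound gives only a limit: the limit of > 40000 nM in this assay, at which 3 of the 4 values shown sit.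

From the compounds shown here alone, whether a smaller group such as methyl on the same aromatic carbon also gives a measurable number stays open. So does the effect of morpholin-4-yl or of a primary amine on the chain carbon bound to the carbonyl carbon.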